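Cyclopropyl for methyl on the amine of compound 3

This account rests on a few compounds, and the source may have more. Where it says the series, first, only, none or still open, it means among the compounds named here.

Of the compounds shown here, three that share one core have been tested in an ADME assay on MT4 cells (Homo sapiens) for cytotoxicity, read by MTT assay, with a stated time of 5 days; a higher number here means that more compound is tolerated, a lower number that less compound is tolerated. Compound 1 `CCNC(c1ccc(C#N)cc1)c1ccnc(Nc2ccc(C#N)cc2)n1` gives 158000 nM in this assay. Compound 2 `CC(O)CNC(c1ccnc(Nc2ccc(C#N)cc2)n1)c1ccccc1Cl` gives 34700 nM in this assay. Compound 3 `CNC(c1ccc(C#N)cc1)c1ccnc(Nc2ccc(C#N)cc2)n1` gives 189000 nM in this assay. Compound 3 and compound 1 are within the scatter of each other, and both sit well above compound 2, whose number is lower than that of compound 3 by a margin beyond the scatter.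

Compound 4 `N#Cc1ccc(Nc2nccc(C(NC3CC3)c3ccc(C#N)cc3)n2)cc1` has not yet been measured. It differs from compound 3 by cyclopropyl in place of methyl on an amine nitrogen; cut one bond further out, the change reads methylamino to cyclopropylamino, bringing in one three-membered non-aromatic ring of carbon only.

Going by the values given here, the one measured step that bears on this is the change of the group on the same amine nitrogen, a 1.2-fold higher number from compound 1 to compound 3 (0.08 log units; within the scatter). That step lies within the scatter, so a further change of the alkyl group on this nitrogen is expected to move the number little. The estimate for compound 4 is therefore 150000 nM, with a range of 70000 nM to 320000 nM, meaning an expected step of a 1.3-fold lower number from compound 3 to compound 4 (0.10 log units; within the scatter) that stays within the scatter.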

Compound 4, half-maximal cytotoxic concentration: 34700 nM
Beside the measured number, compound 4's estimate is 4.3-fold (0.64 log units) above it; the whole stated range lies above it.
By their numbers in this assay, from the lowest: compounds 2 and 4 (each within the scatter of the next); then compounds 1 and 3 (each within the scatter of the next).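

In this assay, the alkyl group on this amine nitrogen proves able to move the number: cyclopropyl in place of methyl gives a 5.4-fold lower number from compound 3 to compound 4 (0.74 log units; beyond the scatter) and cyclopropyl in place of ethyl gives a 4.6-fold lower number from compound 1 to compound 4 (0.66 log units; beyond the scatter), whereas the earlier exchange between the two open chains gave only a 1.2-fold higher number from compound 1 to compound 3 (0.08 log units; within the scatter). Among these three compounds, methyl and ethyl cannot be told apart, and cyclopropyl alone stands apart from both, so the small step between the two chains did not carry over to the three-membered ring of carbon only. Nothing among the data available here accounts for this drop, and the reason for it stays unexplained.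

The compounds shown leave open whether the lower number goes with the ring itself or with the larger number of carbons, a question on which an open propyl or isopropyl group on the same nitrogen would bear. They also leave open how a larger carbon ring such as cyclobutyl, or the bare amine with no alkyl group at all, would stand against compound 3 and compound 4 on this core.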